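This account rests on a few compounds, and the source may have more. Where it says the series, first, only, none or still open, it means among the compounds named here.

Measured in an ADME assay for permeability, using PAMPA, at pH 5; a higher number here means that the compound crosses the layer faster, a lower number that the compound crosses the layer more slowly:
- compound 1 `Nc1nccn2c1c(-c1ccc3ccc(-c4ccccc4)nc3c1F)nc2[C@H]1CC[C@H](CO)CC1`: 880 10^-6 cm/s
- compound 2 `Nc1nccn2c1c(-c1ccc3ccc(-c4ccccc4)nc3c1F)nc2[C@H]1CC[C@H](C(=O)O)CC1`: > 1000 10^-6 cm/s (a limit, not a number)

Compound 2 sits at the limit of > 1000 10^-6 cm/s in this assay, at which 1 of the 2 values shown sits. Compound 3 `Nc1nccn2c1c(-c1ccc3ccc(-c4ccccc4)nc3c1F)nc2[C@H]1CC[C@H](C(N)=O)CC1` differs from compound 2 at one place, with amino in place of hydroxy on a carbonyl carbon, carboxy to carbamoyl: amino in place of hydroxy on a carbonyl carbon.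

Within the data shown here, one measured step bears on this change: an at least 1.1-fold higher number from compound 1 to compound 2 (0.05 log units; that floor lies within the scatter), with carboxy in place of hydroxymethyl on a saturated ring carbon. Among the measured compounds shown here, the size of that step is known only as a floor, and no measured step covers the carbamoyl group. Given compound 1 at 880 10^-6 cm/s, a high reading in this assay is expected to persist, with no step beyond the scatter and no direction assigned. The expected step is an at least 1.3-fold lower number from compound 2 to compound 3 (0.12 log units; that floor lies within the scatter). The estimate for compound 3 is 750 10^-6 cm/s, with an expected range of 350 10^-6 cm/s to 1300 10^-6 cm/s.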

Compound 3, apparent permeability: 45 10^-6 cm/s
The estimate for compound 3 lay 17-fold (1.22 log units) above the measured number, and the stated range ends above it.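

At this place on the saturated ring carbon, the group on the carbonyl carbon can decide the reading in this assay: amino in place of hydroxy gives an at least 22-fold lower number from compound 2 to compound 3 (1.34 log units; beyond the scatter). Compound 2 carries a limit, not a number: the limit of > 1000 10^-6 cm/s in this assay, at which 1 of the 3 values shown sits. Carbamoyl in place of hydroxymethyl gives a 20-fold lower number from compound 1 to compound 3 (1.29 log units; beyond the scatter), whereas carboxy in place of hydroxymethyl gives only an at least 1.1-fold higher number from compound 1 to compound 2 (0.05 log units; that floor lies within the scatter), so a high reading at this place does not carry over to every group.

The compounds shown do not settle what sets the carbamoyl group apart from the carboxy and hydroxymethyl groups. From the compounds shown here alone, it remains open whether a dimethylamide, a nitrile or an aminomethyl group on the same ring carbon would read low like compound 3 or high like compound 1.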